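Replacing Bromine With a Nitrile on the Aryl Ring

A few compounds are considered here, and "the series" means these few. Any claim that something is new, unique, unknown or untested is made for them only; others in the source may bear on it.

The series is tested in an assay on HepG2 cells for agonist activity at nuclear receptor subfamily 1 group I member 3 (Homo sapiens), read by a luciferase reporter, with a stated time of 23 h; a higher number here means that more compound is needed for the effect, a lower number that less compound is needed. Compound 1, with the structure `Clc1ccc(CO/N=C/c2c(-c3ccc(Br)cc3)nc3sccn23)cc1Cl`, gives 480 nM in this assay. Compound 2, `C(=N/OC1Cc2ccccc2C1)\c1c(-c2ccc3ccccc3c2)nc2occn12`, gives 980 nM in this assay. Compound 3, `CC1(C)CCC(C)(C)c2cc(-c3nc4sccn4c3/C=N/OCc3ccc(Cl)c(Cl)c3)ccc21`, is reported as "not active" (no number reported) in this assay, without a number. Among the two compounds with a number, compound 1 stands lowest; its nearest neighbour is compound 2, whose number is higher by a gap that lies beyond the usual scatter. Compound 3 is set apart by a large fused bicyclic substituent in place of the simpler aryl group of compound 1.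

The next compound, compound 4, has the structure `N#Cc1ccc(-c2nc3sccn3c2/C=N/OCc2ccc(Cl)c(Cl)c2)cc1` and awaits measurement in this assay. It differs from compound 1 in one place: cyano in place of bromo on an aromatic carbon. Among the compounds with values here, no measured pair in this set shows what such a change does, so the expectation rests on compound 1 alone. The step from compound 1 to compound 4 is expected to be small, a 1.4-fold higher number from compound 1 to compound 4 (0.13 log units; within the scatter), lying within or only slightly beyond the scatter, with a slight tilt toward a higher number. Compound 4 is therefore estimated at 650 nM, with a range from 220 nM to 2000 nM.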

Compound 4, half-maximal effective concentration: 3400 nM
Beside the measured number, compound 4's estimate is 5.2-fold (0.72 log units) below it; measured number outside the range, above it.
By their numbers in this assay, from the lowest: compound 1; then compound 2; then compound 4.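

In this assay, within the data shown here, the exchange of 4-bromophenyl for 4-cyanophenyl gives a 7.1-fold higher number from compound 1 to compound 4 (0.85 log units; beyond the scatter), the first step in this set that can be read at a single place, and it lies beyond the scatter. It shows that this position, para to a large group, is not indifferent to what it carries: with the rest of compound 1 left unchanged, cyano in place of bromo, which brings in a hydrogen-bond acceptor where bromo has none, is enough to move the number upward. Among these compounds, no measurement in hand accounts for this rise, and the single pair cannot tell which feature of the change lies behind it.

The compounds shown leave open whether the rise is particular to cyano or would also follow from another group at this position, such as an amine, a carboxylic acid, a methoxy group or a longer alkyl chain. They also leave open whether the same exchange would give a step of similar size on the aryl groups of compound 2 or compound 3, or on a different core.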